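A Large Group Gives Way to Bromine

This account rests on a few compounds, and the source may have more. Where it says the series, first, only, none or still open, it means among the compounds named here.

Compound 1 `COc1ccc(C2=C(c3ccc(SC)cc3)CC3CCCN3C2=O)cc1O` gives 6000 nM
Compound 2 `COc1ccc(C2=C(c3ccc(SC)cc3)CC3CCCN3C2=O)cc1OC(=O)CNC(=O)OC(C)(C)C` gives 7000 nM
Compound 3 `COc1ccc(C2=C(c3ccc(SC)cc3)CC3CCCN3C2=O)cc1OC(=O)C1CCCN1C(=O)OC(C)(C)C` gives 5000 nM
Compound 4 `COc1ccc(C2=C(c3ccc(SC)cc3)CC3CCCN3C2=O)cc1Br` has not yet been measured

In a functional assay on NCI-H520 cells (Homo sapiens) for cytotoxicity (on this read-out lower numbers stand for stronger inhibition of growth and higher numbers for weaker inhibition of growth), compound 2 lies within the scatter of both compound 1 and compound 3. The change leading to compound 4 is one bromine atom in place of a group of 12 heavy atoms (7 carbon, 1 nitrogen, 4 oxygen; no ring), on an aromatic carbon, one bromine atom on an aromatic carbon, ortho to a methoxy group. Among the compounds with values here, two measured steps bear on it, a 1.2-fold higher number from compound 1 to compound 2 (0.07 log units; within the scatter) and a 1.4-fold lower number from compound 2 to compound 3 (0.15 log units; within the scatter), and both lie within the scatter. Neither introduces bromine, so the evidence is indirect. No step beyond the scatter is expected, and the estimated step is a 1.2-fold lower number from compound 2 to compound 4 (0.07 log units; within the scatter) in this assay. Compound 4 is estimated at 6000 nM, with an expected range from 2000 nM to 15000 nM.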

Compound 4, concentration for 50% growth inhibition: 700 nM
Compound 4: the middle estimate sits 8.6-fold (0.93 log units) above what was measured; the measured number lies below the stated range.
By their numbers in this assay, from the lowest: compound 4; then compounds 3, 1 and 2 (each within the scatter of the next).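

In this assay, bromo in place of hydroxy on the aromatic carbon gives an 8.6-fold lower number from compound 1 to compound 4 (0.93 log units; beyond the scatter) and bromo in place of the group of 12 heavy atoms gives a 10-fold lower number from compound 2 to compound 4 (1.00 log units; beyond the scatter) in this series. This position, ortho to a methoxy group, therefore responds to substitution, although compound 2 stayed within the scatter of compound 1 and so gave no sign of this. Nothing measured here explains why the number falls.

On these data alone, whether chlorine, iodine or an amine at this position would give a similar step remains open.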